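This account rests on a few compounds, and the source may have more. Where it says the series, first, only, none or still open, it means among the compounds named here.

Measured so far in a functional assay on DU-145 cells (Homo sapiens) for inhibition, read by trypan blue exclusion, with a stated time of 72 h; on this read-out lower numbers stand for stronger inhibition and higher numbers for weaker inhibition:
- compound 1 `Cn1c(=O)c(S(=O)(=O)c2ccc(F)cc2F)cc2cnc(Nc3cccc4[nH]ccc34)nc21` gives 750 nM
- compound 2 `Cc1ccc(S(=O)(=O)c2cc3cnc(Nc4ccc5cc[nH]c5c4)nc3n(C)c2=O)cc1` gives 15000 nM
- compound 3 `Cc1ccc(S(=O)(=O)c2cc3cnc(Nc4ccc5[nH]ccc5c4)nc3n(C)c2=O)cc1` gives 750 nM

Compound 3 stands level with compound 1, and together they hold the lowest number of the three, while compound 2 lies well above them. Compound 4 `Cc1ccc(S(=O)(=O)c2cc3cnc(Nc4cccc5[nH]ccc45)nc3n(C)c2=O)cc1` has the same atoms as compound 3, joined differently: 1H-indol-4-yl in place of 1H-indol-5-yl on a nitrogen on an aromatic ring. Among the compounds with values here, the one measured step of this kind, a 20-fold lower number from compound 2 to compound 3 (1.30 log units; beyond the scatter), shows that moving the indole attachment can matter greatly. Compound 1, which also carries 1H-indol-4-yl, gives 750 nM, although its sulfonyl side differs, so this guide is indirect. Only a small rise is therefore expected, and the estimated change is a 1.3-fold higher number from compound 3 to compound 4 (0.12 log units; within the scatter). For compound 4 the estimated value in this assay is 1000 nM, with an expected range of 300 nM to 5000 nM.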

Compound 4, half-maximal inhibitory concentration: 10000 nM
Compound 4: middle estimate off by 10-fold (1.00 log units), on the low side; the measured number lies above the stated range.
By their numbers in this assay, from the lowest: compounds 1 and 3 (each within the scatter of the next); then compounds 4 and 2 (each within the scatter of the next).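

In this assay, a step of a 13-fold higher number from compound 3 to compound 4 (1.12 log units; beyond the scatter) shows that, with 4-methylphenyl on the sulfonyl sulfur, moving the indole attachment from 1H-indol-5-yl to 1H-indol-4-yl loses most of the inhibition, while a 1.5-fold lower number from compound 2 to compound 4 (0.18 log units; within the scatter) leaves 1H-indol-4-yl and 1H-indol-6-yl level. The sulfonyl side also matters with 1H-indol-4-yl, as a 13-fold higher number from compound 1 to compound 4 (1.12 log units; beyond the scatter) shows for 4-methylphenyl in place of 2,4-difluorophenyl. No measured evidence explains either effect. As far as these compounds go, whether 2,4-difluorophenyl would pair equally well with 1H-indol-5-yl remains open, as does how an amine or carboxylic acid on the indole would behave.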